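Halogen Exchange on the Carbonyl-Bound Ring at Low Concentration

The source may report more compounds than this note shows. Statements on the series, on what has been measured and on what is new or still open speak of the compounds shown alone.

Compound 1: `COc1ccc(-c2cc(/C=C/C(=O)c3ccc(OC)c(OC)c3)[nH]n2)cc1` — 91%
Compound 2: `COc1cc(-c2cc(/C=C/C(=O)c3ccc(Cl)c(Cl)c3)[nH]n2)cc(OC)c1OC` — 98%
Compound 3: `COc1ccc(-c2cc(/C=C/C(=O)c3ccc(N)cc3)[nH]n2)cc1` — 91%

Three compounds were tested in a functional assay on IGROV-1 cells (Homo sapiens) for cytotoxicity, read by sulforhodamine B assay, with a stated time of 48 h, tested at 0.1 uM; a higher number here means a weaker effect of the compound at the concentration tested, a lower number a stronger effect. In this assay compound 1 gives 91%, compound 2 gives 98% and compound 3 gives 91%. Compound 2 stands highest of the three numbers, but its nearest neighbour, compound 1, sits within the scatter of it, and so does the furthest, compound 3; at this concentration the three compounds cannot be told apart in this assay.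

The next compound, compound 4 with the structure `COc1cc(-c2cc(/C=C/C(=O)c3ccc(F)c(F)c3)[nH]n2)cc(OC)c1OC`, has not yet been measured. It is made from compound 2 by one change: 3,4-difluorophenyl in place of 3,4-dichlorophenyl on a carbonyl carbon. Apart from this exchange of one halogenated ring for another on the carbonyl carbon, the two structures are the same.

No change between measured compounds is available to guide the step. All three measured numbers lie close to one another, so the step from compound 2 to compound 4 in this assay is expected to be small, in either direction, and not beyond the scatter. Compound 4 is estimated to give 94%, within 84% to 104%, which means an expected step of a number 4 percentage points lower from compound 2 to compound 4 (within the scatter).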

Compound 4, a percentage reported as activity, at one concentration (the size of the read-out at that concentration, not a potency): 97%
Estimate against measurement, compound 4: 3 percentage points below; the measured number falls inside the stated range.
By their numbers in this assay, from the lowest: compounds 1, 3, 4 and 2 (each within the scatter of the next).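

Among the compounds shown here, the exchange gives the first step between two compounds that differ in one place: in this assay, 3,4-difluorophenyl in place of 3,4-dichlorophenyl on a carbonyl carbon gives a number 1 percentage points lower from compound 2 to compound 4 (within the scatter) and so stays within the scatter. The earlier compounds shown here differed from one another in more than one place and could not speak for this position alone, whereas here one halogen replaces the other on the same ring, with the same count of heavy atoms and no hydrogen-bond donors or acceptors on either group, and the read-out at this concentration cannot tell the two compounds apart. Nothing measured here offers a reason for this result.

On these data alone, whether a phenyl ring carrying a nitrile or a carboxylic acid on the same carbonyl carbon would give a step beyond the scatter remains open. Also open is whether compound 2 and compound 4 would still be indistinguishable at any other concentration, since only a single concentration is shown for them.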